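Swapping a Methyl for Two Methoxy Groups on the Benzyl Ring

A few compounds are considered here, and "the series" means these few. Any claim that something is new, unique, unknown or untested is made for them only; others in the source may bear on it.

Measured compounds:
- Compound 1, `OC[C@H]1O[C@@H](n2cnc3c(NCc4ccc(Cl)cc4)ncnc32)[C@H](O)[C@@H]1O`: 10200 nM
- Compound 2, `OC[C@H]1O[C@@H](n2cnc3c(NCc4ccc(Br)cc4)ncnc32)[C@H](O)[C@@H]1O`: 20600 nM
- Compound 3, `Cc1ccc(CNc2ncnc3c2ncn3[C@@H]2O[C@H](CO)[C@@H](O)[C@H]2O)cc1`: > 166000 nM

All three share one core and differ only in the group on the benzyl ring. In a functional assay on CCRF-CEM cells (Homo sapiens) for antiproliferative activity, with a stated time of 72 h (a lower number here means a stronger inhibitor, a higher number a weaker inhibitor), compound 1 gives 10200 nM, and compound 2 gives 20600 nM, a change of a 2.0-fold higher number from compound 1 to compound 2 (0.31 log units; beyond the scatter). Compound 3 gives only a limit, (the limit of > 166000 nM in this assay, at which 1 of the 3 values shown sits), so its true value is not known. Against that limit the steps were an at least 16-fold higher number from compound 1 to compound 3 (1.21 log units; beyond the scatter) and an at least 8.0-fold higher number from compound 2 to compound 3 (0.90 log units; beyond the scatter); compound 3 therefore stands at the weak end of the set.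

Compound 4, `COc1ccc(CNc2ncnc3c2ncn3[C@@H]2O[C@H](CO)[C@@H](O)[C@H]2O)c(OC)c1`, is not yet measured. It differs from compound 3 by 2,4-dimethoxyphenyl in place of 4-methylphenyl on a saturated chain carbon bound to a nitrogen on an aromatic ring. Among the compounds with values here, no measured step covers a methoxy group; the only guide is that compound 3 lies at the limit, so the direction of any change from compound 3 is unknown. Compound 4 is expected to stay near the limit, a step of an at least 1.1-fold lower number from compound 3 to compound 4 (0.04 log units; that floor lies within the scatter), with an estimate of 150000 nM in this assay, ranging from 30000 nM to 600000 nM.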

Compound 4, half-maximal inhibitory concentration: > 166000 nM
Compound 4 was reported as a limit; the forecaster's own chance of this, stated with the estimate: 55%; middle value at least 1.1-fold (0.04 log units) from the limit.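

In this assay, compound 4 is reported only as a limit, the same one as compound 3: the limit of > 166000 nM in this assay, at which 2 of the 4 values shown sit. The step between these two compounds cannot be read, so neither a gain nor a loss can be assigned to 2,4-dimethoxyphenyl in place of 4-methylphenyl. What the new result adds is a second ring without a halogen that fails to reach the measured range, with an at least 8.0-fold higher number from compound 2 to compound 4 (0.90 log units; beyond the scatter) and an at least 16-fold higher number from compound 1 to compound 4 (1.21 log units; beyond the scatter), so among these four compounds only those carrying 4-bromophenyl and 4-chlorophenyl give a measured number.

The compounds shown do not tell whether a single methoxy group on the ring would behave like the pair. They also leave open whether a smaller halogen such as fluorine, or a different group such as a nitrile, would keep a measurable value.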